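A few compounds are considered here, and "the series" means these few. Any claim that something is new, unique, unknown or untested is made for them only; others in the source may bear on it.

Notes on the series. Among the compounds with values here, compound 1 `CC#C[C@H]1CN(S(=O)(=O)c2ccc(N)nc2)CCN1c1ccc([C@@](O)(CO)C(F)(F)F)cc1` holds the lowest of the two numbers so far obtained in an assay on isolated protein for inhibition of glucokinase regulatory protein (Homo sapiens), read by AlphaScreen, with stated times of 20 min and 4 h; a lower number here means a stronger inhibitor, a higher number a weaker inhibitor: compound 1 gives 6 nM. The nearest measured compound, compound 2 `CC#C[C@H]1CN(S(=O)(=O)c2ccc(N)nc2)CCN1c1ncc(C(O)(C(F)(F)F)C(F)(F)F)s1`, gives 81 nM in this assay, a gap that lies beyond the scatter. Compound 3 `CC#C[C@H]1CN(S(=O)(=O)c2ccc(N)nc2)CCN1c1ccc(S(C)(=N)=O)cc1` has not yet been measured. It differs from compound 1 in a single place: a group of 4 heavy atoms (1 carbon, 1 nitrogen, 1 oxygen, 1 sulfur; no ring) in place of a group of 8 heavy atoms (3 carbon, 2 oxygen, 3 fluorine; no ring), on an aromatic carbon. Within the data shown here, no pair of measured compounds differs in only one place, so this change has no direct precedent here and its effect can only be guessed from the two values in hand. The step of a 3.3-fold higher number from compound 1 to compound 3 (0.52 log units; beyond the scatter) is expected to be a modest loss, perhaps just beyond the scatter, since the group that leaves carries two hydrogen-bond donors and the group that enters carries one. Compound 3 is estimated at 20 nM in this assay, with a range from 5 nM to 80 nM.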

Compound 3, half-maximal inhibitory concentration: 310 nM
Compound 3: middle estimate off by 16-fold (1.19 log units), on the low side; measured number outside the range, above it.
By their numbers in this assay, from the lowest: compound 1; then compound 2; then compound 3.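

Putting the group of 4 heavy atoms in place of the group of 8 heavy atoms, on an aromatic carbon para to a large group, gives a 52-fold higher number from compound 1 to compound 3 (1.71 log units; beyond the scatter) in this assay. Within the data shown here, this is the first single-place comparison, and it shows that the number in this assay depends strongly on the group at this position. The change alters the heavy-atom count, the hydrogen-bond donors and the defined stereocentre all at once, and nothing available explains the large rise in the number.

As far as these compounds go, it remains open which of these differences accounts for the step, and whether a carboxylic acid or an amine on the same aromatic carbon would fall nearer compound 1 or compound 3. From the compounds shown here alone, the effect of the opposite configuration at the stereocentre of compound 1 is also open.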